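Hexylsulfonyl in place of hexyloxy: a weak series

A few compounds are considered here, and "the series" means these few. Any claim that something is new, unique, unknown or untested is made for them only; others in the source may bear on it.

Measured so far in an assay on microsomes from liver for inhibition of sterol O-acyltransferase 1 (Rattus norvegicus); a higher number here means a weaker inhibitor, a lower number a stronger inhibitor:
compound 1, `CCCCCCn1nc(-c2ccccc2)c(-c2ccccc2)c(C)c1=O`, gives 56000 nM
compound 2, `CCCCCCOc1cc(-c2ccccc2)c(-c2ccccc2)nn1`, gives 72000 nM
compound 3, `CCCCCCCCC[S+]([O-])c1cc(-c2ccccc2)c(-c2ccccc2)nn1`, gives 87000 nM

All three numbers are weak and sit close together. Compound 2 stands with compound 1 and compound 3, each gap within the usual scatter, so no order among the three can be read from these numbers. Compound 4, `CCCCCCS(=O)(=O)c1cc(-c2ccccc2)c(-c2ccccc2)nn1`, has not yet been measured. It differs from compound 2 by hexylsulfonyl in place of hexyloxy on an aromatic carbon. Among the compounds with values here, no measured pair isolates this change; compound 3 carries a sulfur-bearing group on the same core and gives a number in the same weak range as compound 2. The step from compound 2 to compound 4 is therefore expected to be small, in no direction beyond the scatter: a 1.0-fold higher number from compound 2 to compound 4 (0.02 log units; within the scatter). Compound 4 is expected to give 75000 nM, within 30000 nM to 200000 nM.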

Compound 4, half-maximal inhibitory concentration: 60000 nM
Estimate against measurement, compound 4: 1.3-fold (0.10 log units) above; measured number inside the range.
By their numbers in this assay, from the lowest: compounds 1, 4, 2 and 3 (each within the scatter of the next).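

In this assay, within the data shown here, hexylsulfonyl in place of hexyloxy gives a 1.2-fold lower number from compound 2 to compound 4 (0.08 log units; within the scatter) and is the first change isolated by a measured pair. On this aromatic carbon next to the ring nitrogen, the two groups cannot be told apart, and the larger hexylsulfonyl group brings no gain beyond the scatter. No measured evidence bears on this result.

Going by these compounds, whether an amine or a carboxylic acid on this carbon would move the number beyond the scatter stays open. So does whether any change to the phenyl groups would do so.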